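Notes on the series: the step from compound 3 to compound 4

The source may report more compounds than this note shows. Statements on the series, on what has been measured and on what is new or still open speak of the compounds shown alone.

Measured compounds:
- compound 1 `CC(C)=CCC/C(C)=C/CC1Cc2c(OCc3ccccc3)cc(=O)n(CCCO)c2CC1(C)C`: 46.5%
- compound 2 `CC(C)=CCC/C(C)=C/CC1Cc2c(OCC=C(C)C)cc(=O)n(CCCO)c2CC1(C)C`: 30.3%
- compound 3 `COc1ccc(OCCCOc2cc(=O)n(CCCO)c3c2CC(C/C=C(\C)CCC=C(C)C)C(C)(C)C3)cc1`: 20%

In a functional assay on PANC-1 cells (Homo sapiens) for inhibition, read by MTT assay, with a stated time of 24 h, tested at 10 uM (a higher number here means more inhibition at the concentration tested (going by the name of the read-out), a lower number less inhibition), compound 3 stands lowest of the three numbers. Both steps toward it run downward: a number 26.5 percentage points lower from compound 1 to compound 3 (beyond the scatter) and a number 10.3 percentage points lower from compound 2 to compound 3 (beyond the scatter), each beyond the scatter, while a number 16.2 percentage points lower from compound 1 to compound 2 (beyond the scatter) is the smaller of the three measured steps. All three measured steps exchange the group on a saturated chain carbon bound to an oxygen on an aromatic ring.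

Compound 4 `CC(C)=CCC/C(C)=C/CC1Cc2c(OCCCOc3ccc([N+](=O)[O-])cc3)cc(=O)n(CCCO)c2CC1(C)C` differs from compound 3 in another place: nitro in place of methoxy on an aromatic carbon. Within the data shown here, none of the measured steps touches the six-membered aromatic ring of carbon only, so no measured step bears directly on this change. The available data therefore give no ground to expect a step beyond the scatter in this assay in either direction; the expectation is that compound 4 stays near compound 3, with the expected step of a number 2 percentage points higher from compound 3 to compound 4 (within the scatter) lying within the usual scatter.

For compound 4 the estimated value in this assay is 22%, expected to fall between 8% and 38%.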

Compound 4, a percentage reported as inhibition, at one concentration (the size of the read-out at that concentration, not a potency): 65.1%
Compound 4: middle estimate off by 43.1 percentage points, on the low side; measured number above the stated range.
By their numbers in this assay, from the lowest: compound 3; then compound 2; then compound 1; then compound 4.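

In this assay, among these compounds, the group on the aromatic carbon para to a large group carries much of the variation in this set: a number 45.1 percentage points higher from compound 3 to compound 4 (beyond the scatter) with nitro in place of methoxy, a large step at a place no earlier step touched. The low standing of compound 3 therefore does not extend to every phenoxy-bearing side chain, since the 2-(4-nitrophenoxy)ethyl group gives a number 34.8 percentage points higher from compound 2 to compound 4 (beyond the scatter) and a number 18.6 percentage points higher from compound 1 to compound 4 (beyond the scatter) and places compound 4 highest of the four. Nothing measured here accounts for the size or direction of these steps.

Still open, going by these compounds, is how an amine or a carboxylic acid on that aromatic carbon would compare with nitro and methoxy. Also open, on these data alone, is whether the higher number for compound 4 would persist with a longer chain in place of the 2-(4-nitrophenoxy)ethyl group.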